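The source may report more compounds than this note shows. Statements on the series, on what has been measured and on what is new or still open speak of the compounds shown alone.

Compound 2 `CCCn1c(=O)[nH]c2nc(-c3ccc(S(=O)(=O)N4CCN(c5ccc(Br)cc5)CC4)cc3)[nH]c2c1=O` is one of three compounds tested in an assay on CHO cells for displacement of a labelled ligand from adenosine receptor A3 (Homo sapiens), read by scintillation counting, with a stated time of 45 min, tested at 1 uM, in the presence of a further agent that is not named here; on this read-out higher numbers stand for more inhibition at the one concentration tested (going by the name of the read-out) and lower numbers for less inhibition. In this assay compound 2 gives 29%, the second highest of the three numbers. Compound 1 `CCCn1c(=O)c2[nH]c(-c3ccc(S(=O)(=O)N4CCN(c5ccc(Cl)cc5)CC4)cc3)nc2n(C)c1=O` gives 39%, a number that lies within the usual scatter of the value for compound 2, so the two cannot be ordered. Compound 3 `CCCn1c(=O)[nH]c2nc(-c3ccc(S(=O)(=O)N4CCN(c5ccccc5)C(C)C4)cc3)[nH]c2c1=O` gives -2%, a number beyond the scatter below compound 2, and compound 3 also carries a methyl on the six-membered ring with two nitrogens together with an unsubstituted phenyl on the amine nitrogen.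

Compound 4 `CCCn1c(=O)[nH]c2nc(-c3ccc(S(=O)(=O)N4CCN(C(C)c5ccccc5)CC4)cc3)[nH]c2c1=O` has not been measured. It differs from compound 2 in one place: 1-phenylethyl in place of 4-bromophenyl on an amine nitrogen in a ring. Among the compounds with values here, no pair of measured compounds shows this same change, so the size of the step is open. Since the phenyl variant compound 3 gives -2%, a fall is expected for compound 4, with a step of a number 17 percentage points lower from compound 2 to compound 4 (beyond the scatter) that is expected to exceed the scatter. Compound 4 is therefore estimated to give 12%, with a range from -10% to 35%.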

Compound 4, a percentage reported as inhibition, at one concentration (the size of the read-out at that concentration, not a potency): 0%
Beside the measured number, compound 4's estimate is 12 percentage points above it, within the range that was stated.
By their numbers in this assay, from the lowest: compounds 3 and 4 (each within the scatter of the next); then compounds 2 and 1 (each within the scatter of the next).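

In this assay, within the data shown here, the swap to 1-phenylethyl from 4-bromophenyl on an amine nitrogen in a ring is the first single change that can be read, and it gives a number 29 percentage points lower from compound 2 to compound 4 (beyond the scatter) with the rest of the molecule unchanged. The read-out thus responds to what sits at this position, even though both groups hold one six-membered aromatic ring of carbon only and neither counts a hydrogen-bond donor, a hydrogen-bond acceptor or a net charge. Nothing measured here accounts for the step.

This one change removes the bromine and also replaces the directly attached aromatic ring with a branched group, so the compounds shown cannot separate these two parts. From the compounds shown here alone, a benzyl group or a 4-methoxyphenyl group at this nitrogen could help to tell them apart, and how either would read remains open.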